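Hexyloxy Replaces Cyclopropylamino on a Shared Core

The source may report more compounds than this note shows. Statements on the series, on what has been measured and on what is new or still open speak of the compounds shown alone.

Compound 2 `Nc1nc(NC2CC2)c2ncn(/C=C3/CC3(CO)CO)c2n1` stands only at a limit in an ADME assay on MOLT-3 cells (Homo sapiens) for cytotoxicity, with a stated time of 7 days; on this read-out higher numbers stand for lower toxicity in this test and lower numbers for higher toxicity in this test: it gives > 20000 nM, which is a limit of the assay rather than a number. Compound 1 `Nc1nc(OCc2ccccc2)c2ncn(/C=C3/CC3(CO)CO)c2n1` likewise gives a limit, > 20000 nM, in this assay. The step that the two limits leave unreadable from compound 1 to compound 2 is thus not readable, and the limit of > 20000 nM in this assay, at which 2 of the 2 values shown sit, is all the two values offer. Compound 3 `CCCCCCOc1nc(N)nc2c1ncn2/C=C1/CC1(CO)CO` differs from compound 2 as follows: hexyloxy in place of cyclopropylamino on an aromatic carbon. Among the measured compounds shown here, no measured step bears on this change. Compound 3 is expected to remain at the limit, an estimated 30000 nM (range 12000 nM to 100000 nM), which is an expected step that the limit leaves unreadable from compound 2 to compound 3.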

Compound 3, half-maximal cytotoxic concentration: > 20000 nM
Compound 3: only a limit was reported; the forecaster's own chance of this, stated with the estimate: 85%; the middle value is on the limit's open side.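

Compound 3, like compound 1 and compound 2, gives only a limit, so no step among them can be read: the limit of > 20000 nM in this assay, at which 3 of the 3 values shown sit.

The compounds shown leave open whether benzyloxy, cyclopropylamino and hexyloxy on the shared core differ in cytotoxicity at all.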